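A Methylphenyl in Place of Fluorophenyl on the Shared Core

The source may hold more compounds than are shown below. What is called first, only, known or untested is meant among the compounds shown, and "the series" means these compounds.

In a functional assay on NCI-H460 cells (Homo sapiens) for cytotoxicity, read by MTT assay, with a stated time of 72 h (a lower number here means a stronger inhibitor, a higher number a weaker inhibitor), compound 1 `COc1cc2c(Oc3ccc(NC(=O)c4cc(-c5ccccc5F)ccn4)cc3F)ccnc2cc1OCCCN1CCCCC1` gives 130 nM. Compound 2 `COc1cc2c(Oc3ccc(NC(=O)c4cc(-c5ccccc5F)ccn4)cc3F)ccnc2cc1OCCCN1CCN(C)CC1` carries a 4-methylpiperazin-1-yl where a piperidin-1-yl stands in compound 1; in this assay compound 2 gives 140 nM. The step of a 1.1-fold higher number from compound 1 to compound 2 (0.03 log units; within the scatter) leaves the two numbers within the scatter of each other, so neither compound can be set above the other. Compound 3 `COc1cc2c(Oc3ccc(NC(=O)c4cc(-c5ccc(C)cc5)ccn4)cc3F)ccnc2cc1OCCCN1CCCCC1` differs from compound 1 at a different place: 4-methylphenyl in place of 2-fluorophenyl on an aromatic carbon. Among the measured compounds shown here, no measured step touches this part of the shared core; the only step known, a 1.1-fold higher number from compound 1 to compound 2 (0.03 log units; within the scatter), concerns the amine at the end of the chain and carries no information about the aryl group. The expectation for compound 3 therefore rests on the number of compound 1 alone, with nothing to anchor the direction of change. For the measured compounds named here, with no comparable step to lean on, compound 3 is expected to move by a 1.4-fold higher number from compound 1 to compound 3 (0.14 log units; within the scatter), a step that is estimated to lie within or close to the scatter but with a range wide enough for movement either way. Compound 3 is thus estimated at 180 nM, between 50 nM and 700 nM.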

Compound 3, half-maximal inhibitory concentration: 160 nM
Compound 3: the middle estimate sits 1.1-fold (0.05 log units) above what was measured, within the range that was stated.
By their numbers in this assay, from the lowest: compounds 1, 2 and 3 (each within the scatter of the next).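

In this assay, among the compounds shown here, the exchange of 2-fluorophenyl for 4-methylphenyl on the aromatic carbon opposite the ring nitrogen gives a 1.2-fold higher number from compound 1 to compound 3 (0.09 log units; within the scatter) and provides the first reading at this position, which the earlier step at the end of the chain did not touch. The two groups have the same count of heavy atoms and each has one six-membered aromatic ring of carbon only, and within the scatter this assay does not separate them, so the position accepts this particular exchange with no readable shift in the number. Nothing available here speaks to the reason for this result.

The exchange alters both the substituent and its place on the phenyl ring, so the two changes stay entangled, and 4-fluorophenyl or 2-methylphenyl would be needed to pull them apart. From the compounds shown here alone, it also remains open whether a more different group at this carbon, such as pyridin-3-yl or a phenyl ring bearing a carboxylic acid, would keep the number where it is, and whether 4-methylphenyl would read the same alongside 4-methylpiperazin-1-yl at the end of the chain.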